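Aryl Thioether in Place of Aryl Ether on a Diamino Core

The source may hold more compounds than are shown below. What is called first, only, known or untested is meant among the compounds shown, and "the series" means these compounds.

Measured compounds:
compound 1 `Nc1cc(N)c2nc(-c3ccccc3)c(Oc3ccc(Cl)c(Cl)c3)nc2c1`: < 100000 nM
compound 2 `CCOC(=O)[C@H](CCC(=O)O)NC(=O)c1ccc(Oc2nc3cc(N)cc(N)c3nc2-c2ccccc2)cc1`: 20000 nM

Both were tested in a functional assay on DU-145 cells (Homo sapiens) for inhibition, read by sulforhodamine B assay, with a stated time of 48 h; on this read-out lower numbers stand for stronger inhibition of growth and higher numbers for weaker inhibition of growth. Compound 1 gives only a limit, < 100000 nM, so its place on the scale is not fixed. The evidence here is the limit of < 100000 nM in this assay, at which 1 of the 2 values shown sits. Compound 2 gives 20000 nM. Among the compounds with values here, no pair of measured compounds differs in one place, so no measured step can be drawn; the two values show only that compound 2 has a number while compound 1 has a limit, and nothing about order between them.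

Compound 3 `COc1ccc(Sc2nc3cc(N)cc(N)c3nc2-c2ccccc2)cc1` differs from compound 1 by (4-methoxyphenyl)sulfanyl in place of 3,4-dichlorophenoxy on an aromatic carbon. Within the data shown here, no measured step shows the weight of this change, and the limit on compound 1 leaves even its direction open. The step that the limit leaves unreadable from compound 1 to compound 3 is expected to be small, not beyond the scatter, with no direction claimed. Compound 3 is estimated at 30000 nM, with a range from 8000 nM to 90000 nM, and a limit rather than a number would not be surprising.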

Compound 3, concentration for total growth inhibition: 33100 nM
Compound 3: the middle estimate sits 1.1-fold (0.04 log units) below what was measured; low and high end bracket the measured number.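

Compound 3 has a measured number, but compound 1 has only a limit, so no step from compound 1 to compound 3 can be read: the limit of < 100000 nM in this assay, at which 1 of the 3 values shown sits.

The compounds shown leave open whether (4-methoxyphenyl)sulfanyl in place of 3,4-dichlorophenoxy on the shared core changes growth inhibition at all, and if so, in which direction and by how much.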